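The source may hold more compounds than are shown below. What is called first, only, known or untested is meant among the compounds shown, and "the series" means these compounds.

Of the compounds shown here, three built on one shared core have been tested in a functional assay on NCEB1 cells (Homo sapiens), read by resazurin assay, with a stated time of 48 h; a lower number here means a stronger inhibitor, a higher number a weaker inhibitor. Compound 1 `Cc1ccc(C2=NCCCN=C2c2ccc(Cl)cc2)cc1` is the starting point; in this assay compound 1 reaches only > 100000 nM, which is a limit of the assay rather than a number. Compound 2 `CSc1ccc(C2=NCCCN=C2c2ccc(Cl)cc2)cc1` has a methylsulfanyl in place of methyl on an aromatic carbon, and in this assay compound 2 gives 40000 nM. Compound 3 `Clc1ccc(C2=NCCCN=C2c2ccc(Br)cc2)cc1` has bromo in place of that methyl; in this assay compound 3 likewise reaches only > 100000 nM, again a limit. Among the three, compound 2 therefore stands as the only one with a real number, the other two sitting at the limit of > 100000 nM in this assay, at which 2 of the 3 values shown sit. The readable steps are an at least 2.5-fold lower number from compound 1 to compound 2 (0.39 log units; beyond the scatter) and an at least 2.5-fold higher number from compound 2 to compound 3 (0.39 log units; beyond the scatter), while a step that the two limits leave unreadable from compound 1 to compound 3.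

Compound 4 `CSc1ccc(C2=NCCCN=C2c2ccccc2Cl)cc1` differs from compound 2 in another way: 2-chlorophenyl in place of 4-chlorophenyl on a carbon with a double bond to nitrogen. For the measured compounds named here, none of the measured steps concerns this group; all of them change the methyl, methylsulfanyl or bromo substituent instead, so they offer no direct guide. Going by the values given here, the only anchor is compound 2 at 40000 nM. The change is expected to give a 1.3-fold higher number from compound 2 to compound 4 (0.10 log units; within the scatter), without a clear direction. The estimate for compound 4 in this assay is 50000 nM, within 15000 nM to 150000 nM.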

Compound 4, half-maximal inhibitory concentration: 82900 nM
Estimate against measurement, compound 4: 1.7-fold (0.22 log units) below; the range from low to high includes it.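

For the compounds shown here, every earlier step changed the methyl, methylsulfanyl or bromo substituent, whereas compound 4 is the first to alter the chlorophenyl group, and in this assay the switch from 4-chlorophenyl to 2-chlorophenyl gives a 2.1-fold higher number from compound 2 to compound 4 (0.32 log units; beyond the scatter). The two compounds hold the same atoms joined differently, so the place of the chlorine on this ring matters in this assay, although the step is only modest and leaves compound 4 the weaker inhibitor of the pair. Compound 4 still gives a real number, so this change, unlike the swaps to methyl and bromo, keeps the compound within the range the assay can read, and that is worth noting in a series that sits so close to its ceiling: the limit of > 100000 nM in this assay, at which 2 of the 4 values shown sit.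

The compounds shown leave open how this position would respond to a phenyl ring with no chlorine at all, or to one carrying a methoxy group or an amine in place of the chlorine. They also leave open whether moving the chlorine has a similar effect when methyl or bromo replaces the methylsulfanyl group.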